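Swapping a Cyclohexylamino Group for a Dimethylamino Group

The compounds below may be only part of what the source reports. "The series", "measured", "known", "first", "only" and "open" are said of these compounds alone.

Compound 1 `Nc1nc(NC2CCCCC2)c2ncn(/C=C3/CC3(CO)CO)c2n1` carries a cyclohexylamino group on the shared core. In an ADME assay on HFF cells (Homo sapiens) for cytotoxicity, with a stated time of 8 days (on this read-out higher numbers stand for lower toxicity in this test and lower numbers for higher toxicity in this test), compound 1 gives > 300000 nM, which is a limit of the test and not a number. Compound 2 `CCCCCOc1nc(N)nc2c1ncn2/C=C1/CC1(CO)CO` has pentyloxy in its place, and in this assay compound 2 gives 259000 nM. Compound 3 `Nc1nc(N2CCCC2)c2ncn(/C=C3/CC3(CO)CO)c2n1` carries pyrrolidin-1-yl there; in this assay compound 3 gives > 300000 nM, again a limit. Where compound 1 stands is thus known only as a limit, one it shares with compound 3 (the limit of > 300000 nM in this assay, at which 2 of the 3 values shown sit). The step of an at least 1.1-fold lower number from compound 1 to compound 2 (0.06 log units; that floor lies within the scatter) lies within the scatter, the step that the two limits leave unreadable from compound 1 to compound 3 cannot be read, and the step of an at least 1.1-fold higher number from compound 2 to compound 3 (0.06 log units; that floor lies within the scatter) also lies within the scatter. Compound 4 `CN(C)c1nc(N)nc2c1ncn2/C=C1/CC1(CO)CO` has not yet been measured. The change from compound 1 to compound 4 (dimethylamino in place of cyclohexylamino on an aromatic carbon). Because the steps of an at least 1.1-fold lower number from compound 1 to compound 2 (0.06 log units; that floor lies within the scatter) and an at least 1.1-fold higher number from compound 2 to compound 3 (0.06 log units; that floor lies within the scatter) stayed within the scatter, no step beyond the scatter is expected here either, and the expected step is a number no higher from compound 1 to compound 4 (the limit leaves the size open). Compound 4 is therefore estimated at 300000 nM, between 150000 nM and 600000 nM, and the test may well report only a limit again.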

Compound 4, half-maximal cytotoxic concentration: > 300000 nM
Compound 4 was reported as a limit; the forecaster's own chance of this, stated with the estimate: 65%; the middle value lies on the limit itself.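

With dimethylamino on this aromatic carbon, the six-membered ring of cyclohexylamino and its hydrogen-bond donor are both gone, yet compound 4 ends at the same limit of the test as compound 1 and compound 3, so three different amino groups at this place now give no measurable number: the limit of > 300000 nM in this assay, at which 3 of the 4 values shown sit. The steps from compound 1 and from compound 3 to compound 4 have a limit at both ends and cannot be read. Within the data shown here, the one step that can be read is an at least 1.1-fold higher number from compound 2 to compound 4 (0.06 log units; that floor lies within the scatter) and so in this assay dimethylamino and pentyloxy cannot be told apart at this place, which extends the flat picture from the ringed groups to a small open-chain amine.

How far compound 1, compound 3 and compound 4 actually lie past the limit stays unknown, so any real differences among these three amino groups remain hidden. Also open, from the compounds shown here alone, is whether a quite different group at this place, such as a carboxylic acid or a longer amine chain ending in a second nitrogen, would bring the reading down to a measurable number.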